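The compounds below may be only part of what the source reports. "The series", "measured", "known", "first", "only" and "open" are said of these compounds alone.

Compound 1 `O=C(C=CNc1cc(-c2ccccc2)nn1-c1ccccc1)c1cccs1` is an open-chain enaminone, unlike compound 2 `COc1ccc(-c2nc3c(c(-c4ccccc4)nn3-c3ccccc3)c(-c3ccc(N4CCN(C)CC4)cc3)c2C#N)cc1` and compound 3 `COc1ccc(-c2nc3c(c(-c4ccccc4)nn3-c3ccccc3)c(-c3ccc(N4CCCCC4)cc3)c2C#N)cc1`, which share a fused core. In a functional assay on MCF7 cells (Homo sapiens) for inhibition, read by MTT assay, with a stated time of 48 h (a higher number here means a weaker inhibitor, a lower number a stronger inhibitor), compound 1 gives 15400 nM, the highest of the three numbers; compound 2 gives 2650 nM and compound 3 gives 2760 nM. Compound 4 `Cc1ccc(C(=O)C=CNc2cc(-c3ccccc3)nn2-c2ccccc2)cc1` differs from compound 1 in one place: 4-methylphenyl in place of thiophen-2-yl on a carbonyl carbon. Among the compounds with values here, the only measured step, a 1.0-fold higher number from compound 2 to compound 3 (0.02 log units; within the scatter), concerns a different scaffold and a different group, so it says nothing about swapping the aryl on the carbonyl carbon. Within the data shown here, with no guiding step, compound 4 is expected to sit near compound 1, with a step of a 1.0-fold lower number from compound 1 to compound 4 (0.01 log units; within the scatter), not beyond the scatter. The estimate for compound 4 is 15000 nM, ranging from 5000 nM to 45000 nM.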

Compound 4, half-maximal inhibitory concentration: 30200 nM
Compound 4: middle estimate off by 2.0-fold (0.30 log units), on the low side, within the range that was stated.
By their numbers in this assay, from the lowest: compounds 2 and 3 (each within the scatter of the next); then compounds 1 and 4 (each within the scatter of the next).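

Putting 4-methylphenyl in place of thiophen-2-yl on the carbonyl carbon gives a 2.0-fold higher number from compound 1 to compound 4 (0.29 log units; within the scatter) in this assay. Within the data shown here, this is the first measured change at this position, and it shows that a five-membered sulfur-containing aromatic ring and a six-membered all-carbon aromatic ring can be exchanged here without a step beyond the scatter. No available measurement bears on why the two groups read alike.

Both groups are aromatic rings, so an open butyl chain, a morpholine ring or a benzoic acid at this carbonyl carbon remains an open question. Also open, as far as these compounds go, is whether the same exchange would read alike on a different core.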